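From a Hydroxy Chain to a Carboxy Chain

The source may hold more compounds than are shown below. What is called first, only, known or untested is meant among the compounds shown, and "the series" means these compounds.

In a functional assay on FM3A cells (Mus musculus) for cytotoxicity (on this read-out lower numbers stand for an effect already at smaller amounts and higher numbers for an effect only at larger amounts of compound), compound 3 (`COOC1(OOCCCCCCO)CCCCCCCCCCC1`) gives 1600 nM and holds the lowest of the three numbers, with compound 2 (`COOC1(OOC(C)(C)OC)CCCCCCCCCCC1`) at 7300 nM and compound 1 (`CCCCOOC1(OOC)CCCCCCCCCCC1`) at 20000 nM on the same read-out. Compound 4 (`COOC1(OOCCC(=O)O)CCCCCCCCCCC1`) keeps the shared core but carries carboxy in place of 4-hydroxybutyl on a saturated chain carbon, two bonds along the chain from an oxygen. The same difference reads as 6-hydroxyhexyl to 2-carboxyethyl. For the measured compounds named here, three measured steps concern this side of the molecule: a 2.7-fold lower number from compound 1 to compound 2 (0.44 log units; beyond the scatter) is modest, a 4.6-fold lower number from compound 2 to compound 3 (0.66 log units; beyond the scatter) is also modest, and a 13-fold lower number from compound 1 to compound 3 (1.10 log units; beyond the scatter) is large. Going by the values given here, none of the three compounds carries carboxy, so no measured step shows this change directly. Compound 3 alone carries 6-hydroxyhexyl, and compound 4 is expected to give back part of the gain seen in the step (a 13-fold lower number from compound 1 to compound 3 (1.10 log units; beyond the scatter)). In this assay a modest rise is therefore expected (a 3.8-fold higher number from compound 3 to compound 4 (0.57 log units; beyond the scatter)). Compound 4 is estimated at 6000 nM (expected range 2000 nM to 20000 nM).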

Compound 4, half-maximal effective concentration: 450 nM
Compound 4: the middle estimate sits 13-fold (1.12 log units) above what was measured; the whole stated range lies above it.
By their numbers in this assay, from the lowest: compound 4; then compound 3; then compound 2; then compound 1.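

In this assay the change from 6-hydroxyhexyl to 2-carboxyethyl lowers the number further (a 3.6-fold lower number from compound 3 to compound 4 (0.55 log units; beyond the scatter)), which shows that a chain ending in carboxy on this oxygen is compatible with an effect at smaller amounts than the hydroxy chain gives. Compound 4 now has the lowest number of the four, and its steps from the two earlier compounds (a 16-fold lower number from compound 2 to compound 4 (1.21 log units; beyond the scatter) and a 44-fold lower number from compound 1 to compound 4 (1.65 log units; beyond the scatter)) are both large and both wider than any step among those compounds. Nothing available explains why this change lowers the number.

This single step alters the chain end and the chain length together, so the two cannot be separated. A 5-carboxypentyl chain, a 2-hydroxyethyl chain or an amine at the chain end would each bear on that question.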